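This account rests on a few compounds, and the source may have more. Where it says the series, first, only, none or still open, it means among the compounds named here.

Compound 1 `CCCCCCCC(=O)Nc1nc2ccc(NC(=O)c3c(Cl)cccc3Cl)cc2s1` gives 0.18 ug/mL in a functional assay on WI-38 VA13 cells (Homo sapiens) for cytotoxicity; a lower number here means that less compound is needed, a higher number that more compound is needed for the effect. Compound 2 `CCCOC(=O)Nc1nc2ccc(NC(=O)c3c(Cl)cccc3Cl)cc2s1` gives 0.0025 ug/mL in this assay, a move of a 72-fold lower number from compound 1 to compound 2 (1.86 log units; beyond the scatter), so compound 2 holds the lowest of the two numbers measured. Compound 3 `O=C(Nc1nc2ccc(NC(=O)c3c(Cl)cccc3Cl)cc2s1)Oc1ccccc1` differs from compound 2 by phenyl in place of propyl on an oxygen next to a carbonyl group. Among the measured compounds shown here, no measured step changes this oxygen-bound group; the only known step, a 72-fold lower number from compound 1 to compound 2 (1.86 log units; beyond the scatter), concerns the group on the carbonyl carbon and offers merely a loose guide. A step of a 4.0-fold higher number from compound 2 to compound 3 (0.60 log units; beyond the scatter) is therefore expected, with wide uncertainty. The estimate for compound 3 is 0.01 ug/mL, within 0.001 ug/mL and 0.1 ug/mL.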

Compound 3, half-maximal effective concentration: 1.1 ug/mL
The estimate for compound 3 lay 110-fold (2.04 log units) below the measured number, outside the stated range (above it).
By their numbers in this assay, from the lowest: compound 2; then compound 1; then compound 3.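

In this assay, the group on an oxygen next to a carbonyl group proves decisive: phenyl in place of propyl gives a very large rise (a 440-fold higher number from compound 2 to compound 3 (2.64 log units; beyond the scatter)), so the low number of compound 2 does not carry over to this aromatic ring. Set against the compound carrying heptyl, the number also rises, though more modestly (a 6.1-fold higher number from compound 1 to compound 3 (0.79 log units; beyond the scatter)). Nothing available bears on the reason for these changes.

On these data alone, whether a cyclohexyl ring, a benzyl group or a longer chain such as butyl on this oxygen keeps the number low remains open.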